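One amino group exchanged: compound 2 to compound 3

A few compounds are considered here, and "the series" means these few. Any claim that something is new, unique, unknown or untested is made for them only; others in the source may bear on it.

Compound 1 `O=C(Nc1ccc(NCc2cccnc2Cl)cc1Cl)c1cc(Cl)ccc1O`: 101000 nM
Compound 2 `CC(C)(CCO)Nc1ccc(NC(=O)c2cc(Cl)ccc2O)c(Cl)c1`: 170000 nM

Among the compounds with values here, in an ADME assay on A549 cells (Homo sapiens) for cytotoxicity, read by resazurin assay, with a stated time of 48 h (a higher number here means that more compound is tolerated, a lower number that less compound is tolerated), compound 2 stands level with compound 1, the only other compound measured so far. Within the data shown here, the single measured step is a 1.7-fold higher number from compound 1 to compound 2 (0.23 log units; within the scatter) and it put 3-hydroxy-1,1-dimethylpropyl in place of (2-chloropyridin-3-yl)methyl on a nitrogen on an aromatic ring. Two very different groups thus gave numbers that cannot be told apart.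

Compound 3 `O=C(Nc1ccc(N(CCCO)CCCO)cc1Cl)c1cc(Cl)ccc1O` keeps the shared core and carries bis(3-hydroxypropyl)amino in place of (3-hydroxy-1,1-dimethylpropyl)amino on an aromatic carbon. Among the measured compounds shown here, no measured compound has two chains on this nitrogen, so the evidence is thin. For the measured compounds named here, the one step that bears on this change is the exchange at the same spot (a 1.7-fold higher number from compound 1 to compound 2 (0.23 log units; within the scatter)), and it stayed within the scatter. No step beyond the scatter is therefore expected in this assay, in either direction. The estimated change is small (a 1.1-fold lower number from compound 2 to compound 3 (0.05 log units; within the scatter)). For compound 3 the expected value is 150000 nM (estimated range 70000 nM to 300000 nM).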

Compound 3, half-maximal cytotoxic concentration: 114000 nM
Estimate against measurement, compound 3: 1.3-fold (0.12 log units) above; measured number inside the range.
By their numbers in this assay, from the lowest: compounds 1, 3 and 2 (each within the scatter of the next).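

In this assay, bis(3-hydroxypropyl)amino in place of (3-hydroxy-1,1-dimethylpropyl)amino on this aromatic carbon gives a 1.5-fold lower number from compound 2 to compound 3 (0.17 log units; within the scatter), so a nitrogen with two chains, new in this series, cannot be told apart from a nitrogen with one. The comparison with the ring-bearing group of compound 1 reads the same way, with bis(3-hydroxypropyl)amino in place of ((2-chloropyridin-3-yl)methyl)amino giving a 1.1-fold higher number from compound 1 to compound 3 (0.05 log units; within the scatter), which means that all three groups now tried at this position sit within the scatter of one another in this assay. This position has therefore so far tolerated quite different groups without a readable shift in the number, and no measurement shown offers an explanation for that.

Still open, as far as these compounds go, is whether any group on this nitrogen can move the number beyond the scatter, for example a chain ending in a carboxylic acid or an amine, or a longer chain than those seen here. From the compounds shown here alone, all three compounds keep the shared core, so what a change elsewhere in the molecule would do in this assay also remains unknown.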